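The compounds below may be only part of what the source reports. "The series", "measured", "known", "first", "only" and "open" are said of these compounds alone.

Measured compounds in a functional assay on MCF7 cells (Homo sapiens) for cytotoxicity, read by MTT assay, with a stated time of 72 h, tested at 100 uM; on this read-out higher numbers stand for more inhibition of growth at the one concentration tested and lower numbers for less inhibition of growth:

compound 1 `N/C(=N\NC(=S)N1CCCCCC1)c1ccccn1` — 84%
compound 2 `N/C(=N\NC(=S)N1CCOCC1)c1ccccn1` — 81.6%
compound 3 `N/C(=N\NC(=S)N1CCOCC1)c1ccc(F)cn1` — 61.5%

Compound 1 and compound 2 differ in a larger part of the molecule; the difference between the two cores is not broken down here. In this assay compound 1 and compound 2 give numbers that lie within the scatter of each other, so no order between them is read.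

Compound 3 is compound 2 with one change, (fluoro in place of hydrogen on an aromatic carbon). That step gave a number 20.1 percentage points lower from compound 2 to compound 3 (beyond the scatter).

Compound 4 `N/C(=N\NC(=S)N1CCCCCC1)c1ccc(F)cn1` is not yet measured. It is compound 1 carrying the same kind of change, (fluoro in place of hydrogen on an aromatic carbon); the place of the change is described in the same words for both pairs. For the measured compounds named here, only one measured pair shows this change, so the expectation for compound 4 rests on that single pair.

From compound 1 to compound 4 the step in this assay is expected to be a number 20 percentage points lower from compound 1 to compound 4 (beyond the scatter), set beside a number 20.1 percentage points lower from compound 2 to compound 3 (beyond the scatter) on which it rests.

Compound 4 is therefore estimated at 64% in this assay, expected to fall between 50% and 78%.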

Compound 4, percent growth inhibition at one concentration: 79%
Estimate against measurement, compound 4: 15 percentage points below; the whole stated range lies below it.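

In this assay the fluoro in place of hydrogen on the aromatic carbon gives a number 5 percentage points lower from compound 1 to compound 4 (within the scatter) and so leaves no readable change on the core of compound 1. The size of the step does not carry over unchanged from one core to the other: the same change on two cores in this assay, a number 20.1 percentage points lower (beyond the scatter) from compound 2 to compound 3 and a number 5 percentage points lower (within the scatter) from compound 1 to compound 4, 15.1 percentage points apart, beyond the scatter of two such steps. The outcome of this change therefore differs between these two cores, but two pairs do not show which feature of the cores accounts for the gap, nor how large the step would be on any further core.

As far as these compounds go, it remains open whether a chloro, a methoxy or an amine on the same aromatic carbon would give a step that differs between the two cores in the way fluoro does. Also open, from the compounds shown here alone, is how the fluoro step would run on a core with an open-chain dimethylamino group in place of the ring of compound 1 or compound 2.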